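The compounds below may be only part of what the source reports. "The series", "measured", "known", "first", "only" and "open" are said of these compounds alone.

Measured compounds:
compound 1 `COc1cc(-c2nn(-c3cccc(NC(=O)c4ccc(Cl)c(C(F)(F)F)c4)c3)cc2-c2ccncc2)ccc1Cl`: > 32500 nM, a limit of the assay.
compound 3 `COc1cc(-c2nn(-c3cccc(NC(=O)c4ccccc4)c3)cc2-c2ccncc2)ccc1Cl`: > 100000 nM, a limit of the assay.
compound 2 `O=C(Nc1cccc(-n2cc(-c3ccncc3)c(-c3ccc(Cl)c(O)c3)n2)c1)Nc1cc(C(F)(F)F)cc(C(F)(F)F)c1`: 4670 nM.

Among the compounds with values here, in a functional assay on HT-29 cells (Homo sapiens) for inhibition, read by sulforhodamine B assay, with a stated time of 48 h (on this read-out lower numbers stand for higher toxicity in this test and higher numbers for lower toxicity in this test), compound 2 gives 4670 nM, the only number among the three values. Compound 4 `O=C(Nc1cccc(-n2cc(-c3ccncc3)c(-c3ccc(Cl)c(O)c3)n2)c1)Nc1cccc(C(F)(F)F)c1` is not yet measured and differs from compound 2 by hydrogen in place of trifluoromethyl on an aromatic carbon. Within the data shown here, the only measured step, a step that the two limits leave unreadable from compound 1 to compound 3, is unreadable because of the limit of > 100000 nM in this assay, at which 1 of the 3 values shown sits, and (the limit of > 32500 nM in this assay, at which 1 of the 3 values shown sits), and it changes a different part of the molecule, so no measured step bears on this change. The estimate for compound 4 therefore rests on compound 2 alone, with a step of a 1.9-fold higher number from compound 2 to compound 4 (0.28 log units; within the scatter) expected to lie near or just beyond the scatter, towards higher numbers. Compound 4 is estimated at 9000 nM, range 3000 nM to 27000 nM.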

Compound 4, concentration lethal to 50% of the cells: > 32500 nM
Compound 4: no number, only a limit (the forecaster's own chance of this, stated with the estimate: 15%); middle value at least 3.6-fold (0.55 log units) from the limit.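

In this assay, within the data shown here, hydrogen in place of the trifluoromethyl group meta to a trifluoromethyl group gives an at least 6.9-fold higher number from compound 2 to compound 4 (0.84 log units; beyond the scatter) on the aromatic ring, so this position affects the read-out, which the earlier compounds did not show, as their only step changed a different part. For compound 4 the reading of > 32500 nM is a limit of the assay. The full size of the step stays unknown because compound 4 sits at a limit: the limit of > 32500 nM in this assay, at which 2 of the 4 values shown sit.

A methyl, a methoxy or a nitrile at this position remains untested among the compounds shown, so how much of the trifluoromethyl effect other groups would keep is open.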